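Compound 1 to compound 4: changing the sulfonyl substituent

The compounds below may be only part of what the source reports. "The series", "measured", "known", "first", "only" and "open" are said of these compounds alone.

In a functional assay on DU-145 cells (Homo sapiens) for inhibition, read by trypan blue exclusion, with a stated time of 72 h (on this read-out higher numbers stand for weaker inhibition and lower numbers for stronger inhibition), compound 1 (`Cn1c(=O)c(S(=O)(=O)Cc2ccc(F)cc2F)cc2cnc(Nc3ccc4[nH]ccc4c3)nc21`) gives 1000 nM and shares the lowest number of the three measured compounds with compound 2 (`Cn1c(=O)c(S(=O)(=O)c2ccccc2)cc2cnc(Nc3cnc4[nH]ccc4c3)nc21`), which stands level at 1000 nM within the scatter. Compound 3 (`Cn1c(=O)c(S(=O)(=O)c2ccc(F)cc2F)cc2cnc(Nc3ccc4c(c3)CC(=O)N4)nc21`) reads far higher at 100000 nM in the same test. Compound 4 (`Cn1c(=O)c(S(=O)(=O)Nc2ccc(F)cc2)cc2cnc(Nc3ccc4[nH]ccc4c3)nc21`) carries (4-fluorophenyl)amino in place of 2,4-difluorobenzyl on a sulfonyl sulfur. Going by the values given here, no two measured compounds differ in one place only, so the data offer no direct precedent for this change. The estimated step in this assay is expected to stay within the scatter (no change at the digits printed from compound 1 to compound 4 (within the scatter)). Compound 4 is estimated at 1000 nM (expected range 200 nM to 5000 nM).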

Compound 4, half-maximal inhibitory concentration: 5000 nM
The estimate for compound 4 lay 5.0-fold (0.70 log units) below the measured number, and the stated range covers the measured number.
By their numbers in this assay, from the lowest: compounds 1 and 2 (each within the scatter of the next); then compound 4; then compound 3.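

Going by these compounds alone, on a sulfonyl sulfur, in this assay, (4-fluorophenyl)amino in place of 2,4-difluorobenzyl gives a 5.0-fold higher number from compound 1 to compound 4 (0.70 log units; beyond the scatter), the first step that can be read at this position. The position is therefore not indifferent to this exchange, which adds one hydrogen-bond donor to a substituent that had none. No measured evidence bears on the origin of the step. Still open, from the compounds shown here alone, are the effects of a carboxylic acid or a longer alkyl chain on the sulfonyl sulfur, and whether the step carries over to other groups on the shared core.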